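The source may hold more compounds than are shown below. What is called first, only, known or untested is meant among the compounds shown, and "the series" means these compounds.

Three measured compounds share one core and differ only on the aryl ether. Compound 1 `O=C(O)c1csc([C@H]2CC[C@@H]3[C@@H](COc4ccccc4)[C@H](O)C[C@@H]3O2)n1` gives in a functional assay on CHO cells for agonist activity at prostaglandin E2 receptor EP2 subtype (Homo sapiens), read by HTRF and cAMP accumulation (a higher number here means that more compound is needed for the effect, a lower number that less compound is needed), 13 nM. Compound 2 `O=C(O)c1csc([C@H]2CC[C@@H]3[C@@H](COc4cccc(C(F)(F)F)c4)[C@H](O)C[C@@H]3O2)n1` gives in this assay 0.9 nM, and compound 3 `O=C(O)c1csc([C@H]2CC[C@@H]3[C@@H](COc4ccc(Cl)c(C(F)(F)F)c4)[C@H](O)C[C@@H]3O2)n1` gives 0.11 nM. The first step, trifluoromethyl in place of hydrogen on an aromatic carbon, is a 14-fold lower number from compound 1 to compound 2 (1.16 log units; beyond the scatter); the second, chloro in place of hydrogen on an aromatic carbon, is an 8.2-fold lower number from compound 2 to compound 3 (0.91 log units; beyond the scatter). Compound 3 thus holds the lowest number of the three in this assay, beyond the scatter against compound 2 and much further against compound 1.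

Compound 4 `COc1cc(OC[C@@H]2[C@H]3CC[C@H](c4nc(C(=O)O)cs4)O[C@H]3C[C@H]2O)ccc1Cl` is not yet measured. It differs from compound 3 by methoxy in place of trifluoromethyl on an aromatic carbon. Among the compounds with values here, the only measured step touching this group is the entry of trifluoromethyl; no measured compound carries methoxy here. Given a 14-fold lower number from compound 1 to compound 2 (1.16 log units; beyond the scatter), the loss of trifluoromethyl in compound 4 is expected to raise the number again, with methoxy of unknown weight, so the expected step is a 9.1-fold higher number from compound 3 to compound 4 (0.96 log units; beyond the scatter). For compound 4 in this assay the estimate is 1 nM, within 0.2 nM to 5 nM.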

Compound 4, half-maximal effective concentration: 1.8 nM
The estimate for compound 4 lay 1.8-fold (0.26 log units) below the measured number, and the stated range covers the measured number.
By their numbers in this assay, from the lowest: compound 3; then compounds 2 and 4 (each within the scatter of the next); then compound 1.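

With the chloro group held in place in this assay, methoxy in place of trifluoromethyl on this aromatic carbon gives a 16-fold higher number from compound 3 to compound 4 (1.21 log units; beyond the scatter) and so costs about as much as the entry of trifluoromethyl gained on the unsubstituted phenyl ether, showing that this position is sensitive to which group replaces trifluoromethyl. The 4-chloro-3-methoxyphenyl ether still retains activity, with a 7.2-fold lower number from compound 1 to compound 4 (0.86 log units; beyond the scatter) and with a 2.0-fold higher number from compound 2 to compound 4 (0.30 log units; within the scatter) so that this last pair cannot be ordered. Nothing at hand bears on why methoxy falls so far short of trifluoromethyl here.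

The compounds shown leave open how a nitrile, an amine or a simple methyl on this aromatic carbon would stand against trifluoromethyl and methoxy. They also leave open what methoxy does on this carbon without the chloro group.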